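A few compounds are considered here, and "the series" means these few. Any claim that something is new, unique, unknown or untested is made for them only; others in the source may bear on it.

The measured compounds:
Compound 1 `Nc1nc(N)c2c(-c3cc4ccccc4o3)cn([C@@H]3O[C@H](CO)[C@@H](O)[C@H]3O)c2n1` — in an ADME assay on BJ cells (Homo sapiens), read by MTT assay, with a stated time of 72 h (on this read-out lower numbers stand for stronger inhibition and higher numbers for weaker inhibition), compound 1 gives > 100000 nM, which is a limit of the assay.
Compound 2 `COc1ncnc2c1c(I)cn2[C@@H]1O[C@H](CO)[C@@H](O)[C@H]1O` — in this assay compound 2 gives 91000 nM.
Compound 3 `Cc1nc(N)c2c(-c3cc4ccccc4o3)cn([C@@H]3O[C@H](CO)[C@@H](O)[C@H]3O)c2n1` — in this assay compound 3 gives > 100000 nM, again a limit of the assay and not a number.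

Within the data shown here, compound 3 therefore stands at the limit of > 100000 nM in this assay, at which 2 of the 3 values shown sit, and the only number among the three, that of compound 2, sits close by. Among the measured compounds shown here, the one step among the measured compounds, a step that the two limits leave unreadable from compound 1 to compound 3, connects two limits, so its size cannot be read.

Compound 4 `Cc1nc(N)c2c(-c3ccccc3)cn([C@@H]3O[C@H](CO)[C@@H](O)[C@H]3O)c2n1` differs from compound 3 in one place: phenyl in place of 1-benzofuran-2-yl on an aromatic carbon. For the measured compounds named here, no measured step touches this position, and nothing among the measured compounds lets the effect of this change be read. With compound 3 sitting at a limit in this assay and compound 2 close to it, the account expects compound 4 to remain in the same region, with a number no higher from compound 3 to compound 4 (the limit leaves the size open) as the expected step, not beyond the scatter. The estimate for compound 4 in this assay is 100000 nM, in the range from 30000 nM to 300000 nM, with a real chance that the assay again reports only a limit.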

Compound 4, half-maximal inhibitory concentration: > 100000 nM
Compound 4 ended at the assay's limit; the forecaster's own chance of this, stated with the estimate: 65%; the middle value sits exactly at the limit.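

In this assay, compound 3 and compound 4 both end at a limit of the assay and not at a number, so no step can be read between them: the limit of > 100000 nM in this assay, at which 3 of the 4 values shown sit.

The compounds shown leave open whether phenyl in place of 1-benzofuran-2-yl on an aromatic carbon changes the read-out at all.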